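Benzyloxycarbonyl to tert-butoxycarbonyl: compound 1 to compound 4

This account rests on a few compounds, and the source may have more. Where it says the series, first, only, none or still open, it means among the compounds named here.

Compound 1 `O=C(OCc1ccccc1)N1CCN(C(=S)SCc2cn(Cc3ccc(Cl)cc3)nn2)CC1` is one of three measured members of the series. In a functional assay on ECa-109 cells (Homo sapiens) for inhibition, read by MTT assay, with a stated time of 72 h (on this read-out higher numbers stand for weaker inhibition and lower numbers for stronger inhibition), compound 1 gives only a limit of the assay, > 128000 nM. Compound 2 `COc1cc(Cn2cc(CSC(=S)N3CCN(C(=O)OCc4ccccc4)CC3)nn2)cc(OC)c1OC` likewise gives only a limit in this assay, > 128000 nM. Compound 3 `O=C(OCc1ccccc1)N1CCN(C(=S)SCc2cn(Cc3ccc(Cl)c(Cl)c3)nn2)CC1` gives 29400 nM in this assay. Within the data shown here, compound 1 thus stands at the limit of > 128000 nM in this assay, at which 2 of the 3 values shown sit, and compound 3 is the only member with a number; the steps of an at least 4.3-fold lower number from compound 1 to compound 3 (0.63 log units; beyond the scatter) and an at least 4.3-fold lower number from compound 2 to compound 3 (0.63 log units; beyond the scatter) are readable only as lower bounds, and the step that the two limits leave unreadable from compound 1 to compound 2 is not readable at all.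

Compound 4 `CC(C)(C)OC(=O)N1CCN(C(=S)SCc2cn(Cc3ccc(Cl)cc3)nn2)CC1` differs from compound 1 by tert-butyl in place of benzyl on an oxygen next to a carbonyl group. Among the measured compounds shown here, none of the measured steps touches this position: all three change the group on the saturated chain carbon bound to an aromatic nitrogen, while the benzyloxycarbonyl is shared by compounds 1, 2 and 3. The measured steps therefore give no guide to direction or size for a change at the carbonyl oxygen. The expected step is a step that the limit leaves unreadable from compound 1 to compound 4, leaving the number at or near the limit. For compound 4 the estimate in this assay is 150000 nM, with a range from 40000 nM to 500000 nM.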

Compound 4, half-maximal inhibitory concentration: > 128000 nM
Compound 4: only a limit was reported; the forecaster's own chance of this, stated with the estimate: 70%; the middle value lies beyond the limit too.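

In this assay compound 4 gives > 128000 nM, which is a limit and not a number. Compound 1 also stands at a limit, so no step can be read from compound 1 to compound 4. The compounds shown leave open how benzyloxycarbonyl and tert-butoxycarbonyl compare where the group on the saturated chain carbon gives a measurable number.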